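Extending a methoxy substituent into a methoxypyridinyl ring

The compounds below may be only part of what the source reports. "The series", "measured", "known", "first", "only" and "open" are said of these compounds alone.

Measured compounds:
Compound 1 `Nc1ccc(S(=O)(=O)N2CCN(c3ncc(C(O)(C(F)(F)F)C(F)(F)F)cc3Br)CC2)cn1` gives 32 mL.min-1.g-1 in an ADME assay (liver) for metabolic stability, with Liver microsome (Rattus norvegicus) as the target, using microsomes and NADPH, with a stated time of 30 min, tested at 1 uM; on this read-out lower numbers stand for slow clearance and higher numbers for fast clearance.
Compound 2 `COc1cc(C(O)(C(F)(F)F)C(F)(F)F)cnc1N1CCN(S(=O)(=O)c2ccc(N)nc2)CC1` gives < 14 mL.min-1.g-1 in this assay; this is a limit of the assay and not a number.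
Compound 3 `CS(=O)(=O)Nc1cccc(-c2cc(C(O)(C(F)(F)F)C(F)(F)F)cnc2N2CCN(S(=O)(=O)c3ccc(N)nc3)CC2)c1` gives 81 mL.min-1.g-1 in this assay.

Compound 2 therefore stands at the slow end of the three, at a reporting limit (the limit of < 14 mL.min-1.g-1 in this assay, at which 1 of the 3 values shown sits), so its true value is known only to lie there or lower.

The unmeasured compound 4 `COc1cncc(-c2cc(C(O)(C(F)(F)F)C(F)(F)F)cnc2N2CCN(S(=O)(=O)c3ccc(N)nc3)CC2)c1` differs from compound 2 in one place: 5-methoxypyridin-3-yl in place of methoxy on an aromatic carbon. The new group is a six-membered aromatic ring with one nitrogen carrying a methoxy, set where compound 2 carries only the methoxy itself.

Among the compounds with values here, two measured steps bear on this. The step of an at least 5.7-fold higher number from compound 2 to compound 3 (0.76 log units; beyond the scatter) put an aryl ring in the same place and gave a clearly faster clearance. The related step of a 2.5-fold higher number from compound 1 to compound 3 (0.40 log units; beyond the scatter) points the same way. Both suggest that adding a ring at this position raises the number in this assay beyond the scatter, though a methoxypyridinyl ring is not the same as a methanesulfonamidophenyl ring, so the size is uncertain.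

Compound 4 is therefore expected to show a step of an at least 3.2-fold higher number from compound 2 to compound 4 (0.50 log units; beyond the scatter). The value of compound 4 in this assay is estimated at 45 mL.min-1.g-1, with a likely range from 20 mL.min-1.g-1 to 100 mL.min-1.g-1.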

Compound 4, intrinsic clearance in microsomes: 58 mL.min-1.g-1
For compound 4 the middle estimate is 1.3-fold (0.11 log units) below the measured one, and the stated range covers the measured number.
By their numbers in this assay, from the lowest: compounds 1, 4 and 3 (each within the scatter of the next, the first and the last beyond it). At a limit, below all of these: compound 2.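

The rise in the clearance number that comes with putting a ring at this position in this assay is not tied to the 3-(methanesulfonamido)phenyl group: 5-methoxypyridin-3-yl, with no sulfonamide, gives an at least 4.1-fold higher number from compound 2 to compound 4 (0.61 log units; beyond the scatter). The two ring groups cannot be told apart on this read-out, with a 1.4-fold lower number from compound 3 to compound 4 (0.15 log units; within the scatter), and the new ring cannot be told apart from bromo either, with a 1.8-fold higher number from compound 1 to compound 4 (0.26 log units; within the scatter). The step from the methoxy is only a minimum, as the value for compound 2 is a limit and not a number: the limit of < 14 mL.min-1.g-1 in this assay, at which 1 of the 4 values shown sits.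

The compounds shown leave open whether the ring alone is enough for the higher number or whether what the ring carries also counts, and a plain phenyl or a pyridin-3-yl ring without the methoxy would separate these two readings. They also leave open how small a group can be and still give a number as low as the methoxy does, a question that a methyl or an amine on the same aromatic carbon would address.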